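Nitro for amino on the benzylamine arm of the shared core

The compounds below may be only part of what the source reports. "The series", "measured", "known", "first", "only" and "open" are said of these compounds alone.

Measured compounds in an assay for inhibition of Indoleamine 2,3-dioxygenase 1 (Homo sapiens), with stated times of 10 min and 60 min, tested at 10 uM; on this read-out lower numbers stand for a weaker effect and higher numbers for a stronger effect at the one concentration tested:
- compound 1 `Nc1cccc(CNc2cc(C(F)(F)F)cc3[nH]ncc23)c1`: 24%
- compound 2 `Oc1ccc(CNc2cc(C(F)(F)F)cc3[nH]ncc23)cc1`: 37%
- compound 3 `O=[N+]([O-])c1ccccc1CNc1cc(C(F)(F)F)cc2[nH]ncc12`: 35%

On these numbers compound 1 stands lowest of the three; its nearest neighbour is compound 3, and compound 2 lies furthest from it, both gaps beyond the scatter. Among the compounds with values here, the one step documented within the set, a number 13 percentage points higher from compound 1 to compound 2 (beyond the scatter), is a modest gain from the 4-hydroxyphenyl replacing the 3-aminophenyl.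

Compound 4 `O=[N+]([O-])c1cccc(CNc2cc(C(F)(F)F)cc3[nH]ncc23)c1` is not yet measured. It differs from compound 1 in one place: nitro in place of amino on an aromatic carbon. Within the data shown here, no documented step covers exactly this exchange. Two observations bear on it indirectly. Compound 3 already carries a nitro group on the same phenyl ring and gives 35%, a number above that of compound 1. Compound 2 shows that changing the substituent pattern on this ring moves the read-out by a modest amount, a number 13 percentage points higher from compound 1 to compound 2 (beyond the scatter). Taken together, a modest upward step is expected rather than none, with the caveat that a different placement of the nitro group has not been tested.

Compound 4 is therefore estimated at 33%, within a range of 18% to 48%, which corresponds to an expected step of a number 9 percentage points higher from compound 1 to compound 4 (within the scatter).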

Compound 4, a percentage reported as inhibition, at one concentration (the size of the read-out at that concentration, not a potency): 45%
For compound 4 the middle estimate is 12 percentage points below the measured one; measured number inside the range.
By their numbers in this assay, from the lowest: compound 1; then compounds 3, 2 and 4 (each within the scatter of the next).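

Nitro in place of amino on an aromatic carbon, meta to a large group, gives a number 21 percentage points higher from compound 1 to compound 4 (beyond the scatter) in this assay and so puts a direct reading on this exchange, which the earlier compounds covered only indirectly. The change replaces a group with 1 hydrogen-bond donor and 1 hydrogen-bond acceptor by one with 0 hydrogen-bond donors and 2 hydrogen-bond acceptors, so compound 4 shows that the read-out at this position does not depend on the donor of the amino group. No measurement on hand accounts for the size of this step, and the data offer no explanation for it.

From the compounds shown here alone, whether the step belongs to the nitro group itself or simply to the removal of amino stays open, and a nitrile, a carboxylic acid or a methyl ester on the same aromatic carbon would help separate the two. Compound 3 at 35% and compound 4 at 45% carry nitro in different placements, and all of these are single-concentration read-outs, so the effect of placement on potency also remains unsettled.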